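A Bulkier Ester on a Shorter Linker

The compounds below may be only part of what the source reports. "The series", "measured", "known", "first", "only" and "open" are said of these compounds alone.

Of the compounds shown here, two have been measured so far. Compound 1 `CCCC(=O)OCCOC(=O)c1ccc(C(=O)Nc2ccc3c(c2)C(C)(C)CCC3(C)C)cc1` gives 18600 nM in a functional assay on K562 cells (Homo sapiens) for inhibition, read by MTT assay, with a stated time of 48 h; a higher number here means a weaker inhibitor, a lower number a stronger inhibitor. Compound 2 `CCCC(=O)OCCCOC(=O)c1ccc(C(=O)Nc2ccc3c(c2)C(C)(C)CCC3(C)C)cc1` gives 4570 nM in this assay. Among the measured compounds shown here, the single measured step, a 4.1-fold lower number from compound 1 to compound 2 (0.61 log units; beyond the scatter), shows that lengthening the chain between the two ester groups lowered the number. For the measured compounds named here, compound 2 therefore stands with the lower of the two numbers, and compound 1 is its only neighbour, separated by a step that lies beyond the scatter.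

Compound 3 `CCCC(CCC)C(=O)OCCOC(=O)c1ccc(C(=O)Nc2ccc3c(c2)C(C)(C)CCC3(C)C)cc1` differs from compound 2 in one place: ((1-propylbutyl)carbonyl)oxy in place of ((propylcarbonyl)oxy)methyl on a saturated chain carbon, two bonds along the chain from an oxygen next to a carbonyl group. In effect the chain between the esters returns to the length found in compound 1, while the acyl group grows from propylcarbonyl to (1-propylbutyl)carbonyl. The step of a 4.1-fold lower number from compound 1 to compound 2 (0.61 log units; beyond the scatter) bears on the first part of this change and, read backwards, points to a higher number; nothing measured here speaks to the larger acyl group. A modest rise in this assay is therefore expected, with wide uncertainty. Compound 3 is expected to give 10000 nM, within 3000 nM to 35000 nM, which would be a step of a 2.2-fold higher number from compound 2 to compound 3 (0.34 log units; beyond the scatter).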

Compound 3, half-maximal inhibitory concentration: 664000 nM
Compound 3: middle estimate off by 66-fold (1.82 log units), on the low side; the measured number lies above the stated range.
By their numbers in this assay, from the lowest: compound 2; then compound 1; then compound 3.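

With the chain left unchanged, 1-propylbutyl in place of propyl on a carbonyl carbon gives a 36-fold higher number from compound 1 to compound 3 (1.55 log units; beyond the scatter) in this assay, so this end of the molecule, which the earlier pair left untouched, has a strong bearing on the number. The step of a 150-fold higher number from compound 2 to compound 3 (2.16 log units; beyond the scatter) combines this larger group with the return to the shorter chain, and it is clearly bigger than a 4.1-fold lower number from compound 1 to compound 2 (0.61 log units; beyond the scatter), the chain change alone, so here the swap on the carbonyl carbon counts for far more than the chain length. No separate measurement is available to explain the jump.

The compounds shown do not separate branching from the number of carbons, and a straight heptyl chain or a smaller branched isopropyl group on the carbonyl carbon would help to tell those two apart. As far as these compounds go, it also remains open how 1-propylbutyl behaves on the longer chain of compound 2, and whether the lower number seen with that chain would persist alongside this larger group.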